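The source may hold more compounds than are shown below. What is called first, only, known or untested is meant among the compounds shown, and "the series" means these compounds.

Of the compounds shown here, three have so far been measured in an ADME assay on cells (Homo sapiens) for cytotoxicity, read by polymerase chain reaction, with a stated time of 3 days; on this read-out lower numbers stand for higher toxicity in this test and higher numbers for lower toxicity in this test. Compound 1 `Nc1nc(Cl)c(-c2ncco2)c(N[C@@H]2C[C@H](CO)[C@@H](O)[C@H]2O)n1` gives > 25000 nM in this assay, which is a limit of the test rather than a number. Compound 2 `Nc1nc(Cl)c(-c2nc3ccccc3o2)c(N[C@@H]2C[C@H](CO)[C@@H](O)[C@H]2O)n1` gives 12000 nM in this assay. Within the data shown here, the one measured single-point step, an at least 2.0-fold lower number from compound 1 to compound 2 (0.31 log units; beyond the scatter), is known only as a bound because of the limit of > 25000 nM in this assay, at which 1 of the 3 values shown sits. Compound 3 `Cc1nc(NCC2CC2)nc(N[C@@H]2C[C@H](CO)[C@@H](O)[C@H]2O)c1-c1nc2ccccc2s1` gives 8000 nM in this assay; of the two actual numbers it is the lowest, but its nearest neighbour, compound 2, sits within the scatter, so no order between them can be claimed.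

Compound 4 `Cc1nc(NCCC(F)(F)F)nc(N[C@@H]2C[C@H](CO)[C@@H](O)[C@H]2O)c1-c1nc2ccccc2s1` differs from compound 3 in one place: 2,2,2-trifluoroethyl in place of cyclopropyl on a saturated chain carbon bound to a nitrogen on an aromatic ring. Among the measured compounds shown here, the single measured step concerns a ring swap on an aromatic carbon and says nothing about the chain on the nitrogen, so no measured step bears on this change. The step of no change at the digits printed from compound 3 to compound 4 (within the scatter) is therefore expected to stay within the scatter. Compound 4 is estimated at 8000 nM, with a range from 3000 nM to 22000 nM.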

Compound 4, half-maximal cytotoxic concentration: 9000 nM
For compound 4 the middle estimate is 1.1-fold (0.05 log units) below the measured one, and the stated range covers the measured number.
By their numbers in this assay, from the lowest: compounds 3, 4 and 2 (each within the scatter of the next). At a limit, above all of these: compound 1.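

In this assay, putting 2,2,2-trifluoroethyl in place of cyclopropyl on a saturated chain carbon bound to a nitrogen on an aromatic ring gives a 1.1-fold higher number from compound 3 to compound 4 (0.05 log units; within the scatter). Among these compounds, this is the first measured step at this place, since the earlier step concerned a ring swap on an aromatic carbon, and it shows that a three-membered carbon ring and an open fluorine-bearing chain cannot be told apart in this test. Nothing in the data shown bears on this result.

On these data alone, neither group has hydrogen-bond donors, hydrogen-bond acceptors or a net charge, so it remains open how a chain ending in an amine or a carboxylic acid would read here. As far as these compounds go, a longer chain at this place, such as hexyl, also remains open.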